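Acetyl for Dimethylamino on a Pyrazole-Linked Growth Inhibitor

This account rests on a few compounds, and the source may have more. Where it says the series, first, only, none or still open, it means among the compounds named here.

Measured compounds:
Compound 1: `COc1cc(C)cc(-c2c(-c3ccnc(-c4ccc(N(C)C)cc4)c3)cnn2CC#N)c1` — 514 nM
Compound 2: `Cc1cc(O)cc(-c2nn(CC#N)cc2-c2ccnc(-c3ccc(Oc4ccccc4)cc3)c2)c1` — 11200 nM

Of the compounds shown here, two have been measured in a functional assay on BT-549 cells (Homo sapiens) for inhibition, read by sulforhodamine B assay, with a stated time of 48 h; a lower number here means a stronger inhibitor of growth, a higher number a weaker inhibitor of growth. Compound 1 `COc1cc(C)cc(-c2c(-c3ccnc(-c4ccc(N(C)C)cc4)c3)cnn2CC#N)c1` gives 514 nM, the lower of the two numbers. Compound 2 `Cc1cc(O)cc(-c2nn(CC#N)cc2-c2ccnc(-c3ccc(Oc4ccccc4)cc3)c2)c1` gives 11200 nM, a clearly higher number, a gap well beyond the usual scatter of repeated measurements. Compound 2 differs from compound 1 in several places at once, so nothing about any single change can be drawn from that pair.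

Compound 3 `COc1cc(C)cc(-c2c(-c3ccnc(-c4ccc(C(C)=O)cc4)c3)cnn2CC#N)c1` keeps the shared core of compound 1 and differs from it in one place: acetyl in place of dimethylamino on an aromatic carbon. For the measured compounds named here, no measured pair shows this swap, so the expectation rests on compound 1 alone. A modest step toward a higher number is expected, roughly a 2.3-fold higher number from compound 1 to compound 3 (0.37 log units; beyond the scatter), with the possibility that it stays within the scatter. Compound 3 is thus estimated at 1200 nM, in a range from 350 nM to 4500 nM.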

Compound 3, concentration for total growth inhibition: > 100000 nM
Compound 3 ended at the assay's limit; the forecaster's own chance of this, stated with the estimate: 5%; middle value at least 83-fold (1.92 log units) away from the limit.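

In this assay, compound 3 gives > 100000 nM, which is a limit of the assay and not a number. For the compounds shown here, at this position, on an aromatic carbon para to a large group, placing acetyl in place of dimethylamino gives an at least 190-fold higher number from compound 1 to compound 3 (2.28 log units; beyond the scatter), so the earlier compounds gave no sign of how much this single site can matter. The two groups have the same number of heavy atoms and hydrogen-bond acceptors, so those counts do not separate them, and the true size of the step stays unknown: the limit of > 100000 nM in this assay, at which 1 of the 3 values shown sits.

The compounds shown leave open whether the activity of compound 1 needs dimethylamino itself or would survive with another group here. A plain amino group, a morpholine ring or a methoxy group at this position would begin to answer that.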